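The compounds below may be only part of what the source reports. "The series", "measured", "known", "first", "only" and "open" are said of these compounds alone.

Working notes on the sulfonyl series. Compound 1 `Cc1ccc(S(=O)(=O)c2cnc3cc(F)ccc3c2N2CCC(C)CC2)cc1C` gives 90% in an assay on isolated protein for displacement of a labelled ligand from metabotropic glutamate receptor 5 (Homo sapiens), with a stated time of 60 min, tested at 1 uM; a higher number here means more inhibition at the concentration tested (going by the name of the read-out), a lower number less inhibition; compound 2 `CC1CCN(c2c(S(=O)(=O)c3ccc(Cl)c(Cl)c3)cnc3cc(F)ccc23)CC1` gives 94% in this assay; compound 3 `COc1ccc(S(=O)(=O)c2cnc3cc(F)ccc3c2N2CCC(C)CC2)cc1` gives 90% in this assay. On these numbers compound 3 stands level with compound 1 at the digits printed, the two together the lowest of the three, and the widest gap in the set is a number 4 percentage points lower from compound 2 to compound 3 (within the scatter), so all three lie within the scatter of one another.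

Compound 4 `CC1CCN(c2c(S(=O)(=O)c3cccc(C#N)c3)cnc3cc(F)ccc23)CC1` differs from compound 3 by 3-cyanophenyl in place of 4-methoxyphenyl on a sulfonyl sulfur. Going by the values given here, two measured steps bear on it, since each likewise replaces the group on the sulfonyl sulfur: no change at the digits printed from compound 1 to compound 3 (within the scatter) and a number 4 percentage points lower from compound 2 to compound 3 (within the scatter), neither beyond the scatter. For compound 4 the expected step is therefore no change at the digits printed from compound 3 to compound 4 (within the scatter), none beyond the scatter. Compound 4 is estimated at 90%, between 80% and 97%.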

Compound 4, a percentage reported as inhibition, at one concentration (the size of the read-out at that concentration, not a potency): 92%
For compound 4 the middle estimate is 2 percentage points below the measured one; the range from low to high includes it.
By their numbers in this assay, from the lowest: compounds 1, 3, 4 and 2 (each within the scatter of the next).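

Going by these compounds alone, with 3-cyanophenyl on the sulfonyl sulfur, the only group here carrying a nitrile, this assay shows a number 2 percentage points higher from compound 3 to compound 4 (within the scatter), a number 2 percentage points lower from compound 2 to compound 4 (within the scatter) and a number 2 percentage points higher from compound 1 to compound 4 (within the scatter). The four aromatic groups on this sulfur therefore remain within the scatter of one another, so this change separates none of them at the concentration tested. No supporting evidence bears on why the read-out stays level across this change.

Open, on these data alone, is whether a phenyl bearing a carboxylic acid or an amine would hold this level. Any differences in potency among the four compounds also remain open.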